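The source may hold more compounds than are shown below. What is called first, only, known or untested is meant among the compounds shown, and "the series" means these compounds.

Measured compounds:
compound 1, `N#Cc1cnc(NCc2ccccc2C(F)(F)F)cc1N[C@H]1CC[C@@H](O)CC1` — 140 nM
compound 2, `N#Cc1cnc(NCc2cnccc2C(F)(F)F)cc1NC[C@H]1CC[C@H](O)CC1` — 50 nM

Among the measured compounds shown here, in an assay on isolated protein for inhibition of protein kinase C theta type (Homo sapiens), read by TR-FRET, with a stated time of 2 h (on this read-out lower numbers stand for stronger inhibition and higher numbers for weaker inhibition), compound 2 stands lowest of the two numbers, with compound 1 the only neighbour, and no single-place step between the two has been worked out. Compound 3, `CC1(C)C[C@H](Nc2cc(NCc3cnccc3C(F)(F)F)ncc2C#N)CC[C@@H]1O`, carries 4-hydroxy-3,3-dimethylcyclohexyl in place of (4-hydroxycyclohexyl)methyl on a nitrogen on an aromatic ring. For the measured compounds named here, with no measured step of this kind to lean on, the change from compound 2 to compound 3 is expected to stay small, in either direction, and likely within the scatter, so that the step from compound 2 to compound 3 is estimated as a 1.6-fold higher number from compound 2 to compound 3 (0.20 log units; within the scatter). Compound 3 is therefore expected to read about 80 nM, between 25 nM and 300 nM.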

Compound 3, half-maximal inhibitory concentration: 7 nM
The estimate for compound 3 lay 11-fold (1.06 log units) above the measured number; measured number below the stated range.
By their numbers in this assay, from the lowest: compound 3; then compound 2; then compound 1.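

In this assay, the group on this nitrogen proves able to shift the read-out well beyond the scatter, with a 7.1-fold lower number from compound 2 to compound 3 (0.85 log units; beyond the scatter). Both groups keep a hydroxy-bearing cyclohexane ring, so the step shows that the way this ring is attached and substituted matters at this position. Nothing available explains the step.

Going by these compounds, the change removes the methyl link and adds the two ring methyl groups together, so their separate contributions remain open. On these data alone, how an amine or a methoxy group in place of the hydroxy would read also remains open.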